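Chain homologation and piperidine swap in one series

The compounds below may be only part of what the source reports. "The series", "measured", "known", "first", "only" and "open" are said of these compounds alone.

The series keeps one core and varies the chain and its terminal amine. Compound 1 `COc1ccc(-c2cc(=O)c3ccc(OCCCN4CCC(CCO)CC4)cc3o2)cc1` carries the 4-(2-hydroxyethyl)piperidin-1-yl group; in a functional assay, read by spectrophotometry (on this read-out higher numbers stand for an effect only at larger amounts of compound and lower numbers for an effect already at smaller amounts), compound 1 gives 22.8 nM. Compound 2 `COc1ccc(-c2cc(=O)c3ccc(OCCCCN4CCC(C)CC4)cc3o2)cc1` shows ((4-methylpiperidin-1-yl)methyl in place of 4-(2-hydroxyethyl)piperidin-1-yl on a saturated chain carbon, three bonds along the chain from an oxygen on an aromatic ring); in this assay compound 2 gives 28.1 nM, so that a 1.2-fold higher number from compound 1 to compound 2 (0.09 log units; within the scatter). Compound 3 `COc1ccc(-c2cc(=O)c3ccc(OCCCCN4CCC(CCO)CC4)cc3o2)cc1` has a core that differs from the core of compound 1 by (4-(2-hydroxyethyl)piperidin-1-yl)methyl in place of 4-(2-hydroxyethyl)piperidin-1-yl on a saturated chain carbon, three bonds along the chain from an oxygen on an aromatic ring; in this assay compound 3 gives 23.2 nM, and a 1.0-fold higher number from compound 1 to compound 3 (0.01 log units; within the scatter). Between compound 2 and compound 3, a 1.2-fold lower number from compound 2 to compound 3 (0.08 log units; within the scatter). The three values lie together and no order among them can be read.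

Compound 4 `COc1ccc(-c2cc(=O)c3ccc(OCCCCCN4CCC(C)CC4)cc3o2)cc1` is not yet measured. Relative to compound 3 it shows ((4-methylpiperidin-1-yl)methyl in place of 4-(2-hydroxyethyl)piperidin-1-yl on a saturated chain carbon, four bonds along the chain from an oxygen on an aromatic ring). This is the same kind of change as that from compound 1 to compound 2, not the same: there the group sits on a saturated chain carbon three bonds along the chain from an oxygen on an aromatic ring, here on a saturated chain carbon four bonds along the chain from an oxygen on an aromatic ring. The same kind of change is expected to give a similar small step from compound 3 to compound 4, a 1.2-fold higher number from compound 3 to compound 4 (0.07 log units; within the scatter), because the earlier change gave a 1.2-fold higher number from compound 1 to compound 2 (0.09 log units; within the scatter) and compound 3 starts from 23.2 nM. For compound 4 in this assay the expected value is 27 nM, estimated to fall between 14 nM and 55 nM.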

Compound 4, half-maximal effective concentration: 31.7 nM
Estimate against measurement, compound 4: 1.2-fold (0.07 log units) below, within the range that was stated.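

Set on the longer chain, the swap of 4-(2-hydroxyethyl)piperidin-1-yl for (4-methylpiperidin-1-yl)methyl gives a 1.4-fold higher number from compound 3 to compound 4 (0.14 log units; within the scatter) in this assay, and it reads the same as the earlier step on the other core: the same change on two cores in this assay, a 1.2-fold higher number (0.09 log units; within the scatter) from compound 1 to compound 2 and a 1.4-fold higher number (0.14 log units; within the scatter) from compound 3 to compound 4, 1.1-fold (0.04 log units) apart, within the scatter of two such steps.

Within these two pairs the change carries over from one core to the other with no step that can be told from the scatter, and the same holds for (4-methylpiperidin-1-yl)methyl in place of 4-methylpiperidin-1-yl, a 1.1-fold higher number from compound 2 to compound 4 (0.05 log units; within the scatter), and for the two changes taken together, a 1.4-fold higher number from compound 1 to compound 4 (0.14 log units; within the scatter). Among the compounds shown here, as every one of these steps lies within the scatter, the series shows only that the numbers stay in one range on both cores; it does not show that the change has a real effect of fixed size, and two pairs make no rule for other cores.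

From the compounds shown here alone, it remains open whether the numbers stay in this range with a chain longer than that of compound 4. Going by these compounds, it is equally open what a morpholine or piperazine in place of the piperidine, or a carboxylic acid in place of the hydroxyethyl group, would do on either core.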